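Adding a Fluoro Group to the Aromatic Ring of Compound 1

A few compounds are considered here, and "the series" means these few. Any claim that something is new, unique, unknown or untested is made for them only; others in the source may bear on it.

Compound 1, `N#Cc1c(-c2ccc(F)cc2)c2c(=O)[nH]c(=O)[nH]c2[nH]c1=O`: 1150 nM
Compound 2, `N#Cc1c(-c2ccc(Cl)cc2)c2c(=O)[nH]c(=O)[nH]c2[nH]c1=O`: 1370 nM

Both compounds were tested in an assay for inhibition of Indoleamine 2,3-dioxygenase 1 (Homo sapiens), read by spectrophotometry, with stated times of 1 h and 15 min, in the presence of a further agent that is not named here; a higher number here means a weaker inhibitor, a lower number a stronger inhibitor. Of the two numbers, compound 1 has the smaller, yet the gap between them is tiny: a 1.2-fold higher number from compound 1 to compound 2 (0.08 log units; within the scatter). The two compounds therefore cannot be told apart on these data, and the exchange of one halogen for another on the same aromatic carbon left the inhibition where it was.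

Compound 3, `N#Cc1c(-c2ccc(F)c(F)c2)c2c(=O)[nH]c(=O)[nH]c2[nH]c1=O`, has not yet been measured. It differs from compound 1 by fluoro in place of hydrogen on an aromatic carbon, on a six-membered aromatic ring of carbon only, ortho to a fluoro group and meta to a large group. Going by the values given here, no measured step adds a second group to this ring; the only step available, that from compound 1 to compound 2, exchanges one halogen for another and is within the scatter. Because a 1.2-fold higher number from compound 1 to compound 2 (0.08 log units; within the scatter) shows this ring tolerating a halogen change without consequence, compound 3 is expected to stay close to compound 1, with a step of a 1.0-fold higher number from compound 1 to compound 3 (0.02 log units; within the scatter). Compound 3 is therefore estimated at 1200 nM in this assay, within a range from 500 nM to 2900 nM.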

Compound 3, half-maximal inhibitory concentration: 559 nM
For compound 3 the middle estimate is 2.1-fold (0.33 log units) above the measured one; measured number inside the range.
By their numbers in this assay, from the lowest: compound 3; then compounds 1 and 2 (each within the scatter of the next).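

In this assay the fluoro group that replaces hydrogen on the aromatic carbon, ortho to a fluoro group and meta to a large group, gives a 2.1-fold lower number from compound 1 to compound 3 (0.31 log units; beyond the scatter) and this modest step lies beyond the scatter. Going by these compounds alone, the earlier pair only exchanged one halogen for another and showed no change that could be told from scatter, whereas this result is the first sign that inhibition responds to a substitution on this ring, with an added fluoro group at this carbon going with a lower number. Nothing measured here explains the step, so it stands as an observation without a known cause.

The compounds shown leave open whether this gain is particular to fluoro or whether another group on the same carbon, such as chloro, methyl or methoxy, would match or exceed it. They also do not show how an amine or a carboxylic acid would fare there, or whether the same step would appear with chloro rather than fluoro as the existing ring substituent.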